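Swapping 4-bromophenyl for 3-methoxyphenyl in a small series

A few compounds are considered here, and "the series" means these few. Any claim that something is new, unique, unknown or untested is made for them only; others in the source may bear on it.

Measured in a functional assay on PANC-1 cells (Homo sapiens) for inhibition, read by MTT assay, with a stated time of 24 h; a lower number here means a stronger inhibitor, a higher number a weaker inhibitor:
compound 1 `CC1(C)[C@H]2CC[C@]1(C)N(Cc1cn(-c3ccccc3Br)nn1)C(=O)C2`: 280 nM
compound 2 `CC1(C)[C@H]2CC[C@]1(C)N(Cc1cn(-c3ccc(O)cc3)nn1)C(=O)C2`: 100 nM
compound 3 `CC1(C)[C@H]2CC[C@]1(C)N(Cc1cn(-c3ccc(Br)cc3)nn1)C(=O)C2`: 200 nM

Compound 3 lies within the span set by the other two compounds, and neither of its gaps exceeds the scatter. The data show a 1.4-fold lower number from compound 1 to compound 3 (0.15 log units; within the scatter) and a 2.0-fold higher number from compound 2 to compound 3 (0.30 log units; within the scatter). Among the compounds with values here, only one measured step goes beyond the scatter, and it remains modest: a 2.8-fold lower number from compound 1 to compound 2 (0.45 log units; beyond the scatter).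

The unmeasured compound 4 `COc1cccc(-n2cc(CN3C(=O)C[C@@H]4CC[C@@]3(C)C4(C)C)nn2)c1` keeps the shared core and differs from compound 3 at a single place: 3-methoxyphenyl in place of 4-bromophenyl on an aromatic nitrogen. The change is 3-methoxyphenyl in place of 4-bromophenyl on an aromatic nitrogen. Within the data shown here, no measured compound carries 3-methoxyphenyl, so the three steps offer only indirect guidance. All three are changes to the group on that same aromatic nitrogen, and the largest of them is a 2.8-fold lower number from compound 1 to compound 2 (0.45 log units; beyond the scatter). Among the measured compounds shown here, with only three compounds behind it, that step gives a rough idea of how far such a change has moved the number. It gives no direction for this one. In this assay, no step beyond the scatter is therefore expected. The expected step is a 1.1-fold lower number from compound 3 to compound 4 (0.05 log units; within the scatter). For compound 4 the estimated value is 180 nM. The expected range for compound 4 runs from 70 nM to 450 nM.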

Compound 4, half-maximal inhibitory concentration: 860 nM
Compound 4: the middle estimate sits 4.8-fold (0.68 log units) below what was measured; the whole stated range lies below it.
By their numbers in this assay, from the lowest: compounds 2, 3 and 1 (each within the scatter of the next, the first and the last beyond it); then compound 4.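

In this assay, within the data shown here, 3-methoxyphenyl on the aromatic nitrogen is the first group to separate clearly from all the others, with a 4.3-fold higher number from compound 3 to compound 4 (0.63 log units; beyond the scatter) and a 3.1-fold higher number from compound 1 to compound 4 (0.49 log units; beyond the scatter). The widest gap at this position now comes from this change, at an 8.6-fold higher number from compound 2 to compound 4 (0.93 log units; beyond the scatter), so the group on this nitrogen can move the number further than compounds 1, 2 and 3 alone showed, and compound 4 is the weakest inhibitor of the four. The change adds a hydrogen-bond acceptor by count and replaces bromine with a methoxy group, but no supporting measurement is available to explain the higher number.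

The compounds shown leave open whether the higher number goes with the methoxy group itself or with where it sits on the phenyl ring, and 4-methoxyphenyl and 3-bromophenyl would pull those two apart. As far as these compounds go, it also remains open how other groups on this phenyl ring would read in this assay, for example an amine or a carboxylic acid in place of the methoxy group.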